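A Carboxy Group on the Aromatic Ring of Compound 1

The source may report more compounds than this note shows. Statements on the series, on what has been measured and on what is new or still open speak of the compounds shown alone.

Going by the values given here, compound 1 `O=C(CCCCCCc1ccccc1)N1CCCC1` is measured in an assay on HEK293 cells for inhibition of N-acylethanolamine-hydrolyzing acid amidase (Rattus norvegicus), read by LC-MS, with a stated time of 30 min (on this read-out higher numbers stand for weaker inhibition and lower numbers for stronger inhibition), where compound 1 gives 12900 nM; the only other plain number shown sits within the scatter of it. In this assay compound 2 `O=C(CCCCCCc1ccc(F)cc1)N1CCCC1` gives 8000 nM, and the step of a 1.6-fold lower number from compound 1 to compound 2 (0.21 log units; within the scatter) is within the scatter. Compound 3 `O=C(CCCCCCc1ccccc1Cl)N1CCCC1` gives > 100000 nM, which is a limit of the assay and not a number (the limit of > 100000 nM in this assay, at which 1 of the 3 values shown sits). The step of an at least 7.7-fold higher number from compound 1 to compound 3 (0.88 log units; beyond the scatter) is beyond the scatter. Compound 4 `O=C(O)c1cccc(CCCCCCC(=O)N2CCCC2)c1` differs from compound 1 by carboxy in place of hydrogen on an aromatic carbon. The step to compound 3 bears most on this change and the step to compound 2 less, so a weakening beyond the scatter is expected. Compound 4 is estimated at 40000 nM, between 10000 nM and 150000 nM, an expected step of a 3.1-fold higher number from compound 1 to compound 4 (0.49 log units; beyond the scatter).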

Compound 4, half-maximal inhibitory concentration: > 100000 nM
Compound 4: no number, only a limit; the forecaster's own chance of this, stated with the estimate: 30%; middle value at least 2.5-fold (0.39 log units) from the limit.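

The earlier compounds shown here say nothing about a group on this ring carbon, meta to a large group. In this assay, placing carboxy there gives an at least 7.7-fold higher number from compound 1 to compound 4 (0.88 log units; beyond the scatter), so this position does not tolerate this change without a loss of inhibition beyond the scatter. Compound 4 gives only a limit of the assay and not a number, so the full size of the loss stays unknown: the limit of > 100000 nM in this assay, at which 2 of the 4 values shown sit.

From the compounds shown here alone, whether a methyl ester or an amine at this position would keep inhibition remains open. So does whether carboxy elsewhere on the ring would weaken it as much.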